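This account rests on a few compounds, and the source may have more. Where it says the series, first, only, none or still open, it means among the compounds named here.

Compound 1 `COc1ncnc2c1c(-c1ccoc1)cn2[C@@H]1O[C@H](CO)[C@@H](O)[C@H]1O`, compound 2 `COc1nc(N)nc2c1c(-c1ccoc1)cn2[C@@H]1O[C@H](CO)[C@@H](O)[C@H]1O` and compound 3 `O=c1[nH]cnc2c1c(-c1ccccc1)cn2[C@@H]1O[C@H](CO)[C@@H](O)[C@H]1O` were examined in a functional assay on CEM-DNR-bulk cells (Homo sapiens), read by MTT assay, with a stated time of 72 h; on this read-out higher numbers stand for weaker inhibition and lower numbers for stronger inhibition. In this assay compound 1 reaches only a limit, > 20000 nM. For compound 2 the result is again only a limit, > 20000 nM. Compound 3 likewise returns only a limit, > 20000 nM. The step that the two limits leave unreadable from compound 1 to compound 2 corresponds to amino in place of hydrogen on an aromatic carbon. The difference between the core of compound 1 and the core of compound 3 is not broken down here. Compound 4 `Nc1nc2c(c(-c3ccccc3)cn2[C@@H]2O[C@H](CO)[C@@H](O)[C@H]2O)c(=O)[nH]1` has not been measured; it differs from compound 3 by amino in place of hydrogen on an aromatic carbon, the same kind of change as that from compound 1 to compound 2, although there the carbon is meta to a methoxy group (2 heavy atoms) while here it is meta to a group of 1 heavy atom. Among the compounds with values here, because of the limit of > 20000 nM in this assay, at which 3 of the 3 values shown sit, no measured step in this assay has a readable size, and the step from compound 1 to compound 2 offers no guide. The expected step is therefore a step that the limit leaves unreadable from compound 3 to compound 4, since (the limit of > 20000 nM in this assay, at which 3 of the 3 values shown sit). Compound 4 is estimated at 30000 nM, between 8000 nM and 100000 nM, most likely reported as a limit.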

Compound 4, half-maximal inhibitory concentration: > 20000 nM
Compound 4 was reported as a limit; the forecaster's own chance of this, stated with the estimate: 85%; the middle value does not contradict the limit.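

No step can be read from compound 3 to compound 4 in this assay, because both results are limits and give no size for the change: the limit of > 20000 nM in this assay, at which 4 of the 4 values shown sit.

The compounds shown leave open whether amino in place of hydrogen on an aromatic carbon, or any other difference among them, alters inhibition in this assay.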